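Amide variation in the series: cytotoxicity notes

The source may report more compounds than this note shows. Statements on the series, on what has been measured and on what is new or still open speak of the compounds shown alone.

Compound 1 `CCCCCC(=O)NCCCN1CCN(CCCNc2ccnc3cc(Cl)ccc23)CC1` gives "not determined" (no result reported) in an ADME assay on L6 cells (Rattus norvegicus) for cytotoxicity; a lower number here means a stronger inhibitor, a higher number a weaker inhibitor. Compound 2 `CCc1ccc(C(=O)NCCCN2CCN(CCCNc3ccnc4cc(Cl)ccc34)CC2)cc1` gives 3900 nM in this assay, and compound 3 `O=C(CCCc1c[nH]c2ccccc12)NCCCN1CCN(CCCNc2ccnc3cc(Cl)ccc23)CC1` gives 6500 nM. Within the data shown here, the single measured step, a 1.7-fold higher number from compound 2 to compound 3 (0.22 log units; within the scatter), shows that compound 3 has the higher of the two numbers but sits within the scatter of compound 2, so no order can be claimed between them. Compound 4 `COc1cccc(C(=O)NCCCN2CCN(CCCNc3ccnc4cc(Cl)ccc34)CC2)c1` carries the change (3-methoxyphenyl in place of 3-(1H-indol-3-yl)propyl on a carbonyl carbon). Among the measured compounds shown here, the only step that bears on it is the swap of the amide substituent between compound 2 and compound 3, which stayed within the scatter, so aryl and indolylalkyl amides here look alike. An estimated step of a 1.4-fold lower number from compound 3 to compound 4 (0.13 log units; within the scatter) is therefore expected, no larger than the scatter. Compound 4 is estimated at 4800 nM, with a range of 2200 nM to 10500 nM.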

Compound 4, half-maximal inhibitory concentration: 9300 nM
Beside the measured number, compound 4's estimate is 1.9-fold (0.29 log units) below it, within the range that was stated.
By their numbers in this assay, from the lowest: compounds 2, 3 and 4 (each within the scatter of the next, the first and the last beyond it).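

In this assay, 3-methoxyphenyl in place of 3-(1H-indol-3-yl)propyl on the carbonyl carbon gives a 1.4-fold higher number from compound 3 to compound 4 (0.16 log units; within the scatter), so these two amides cannot be ordered. Among these compounds, the two aryl amides give the first step at this position that clears the scatter, though only modestly: a 2.4-fold higher number from compound 2 to compound 4 (0.38 log units; beyond the scatter). No evidence is available to account for this step. From the compounds shown here alone, it remains open whether an amine or a carboxylic acid in place of 3-methoxyphenyl on the carbonyl carbon would move the number further. Going by these compounds, how a pyridine ring in that place would compare also remains open.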